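Acetyl Capping of an Aromatic Amine and Oral Exposure

The source may report more compounds than this note shows. Statements on the series, on what has been measured and on what is new or still open speak of the compounds shown alone.

Compound 1 `Cc1ccc(-c2cc(Cl)ccc2OCc2ccc(F)cc2F)n1-c1cc(C(=O)O)ccc1F`: 230 nM
Compound 2 `Cc1ccc(-c2cc(Cl)ccc2OCc2ccccc2)n1-c1cc(Br)cc(C(=O)O)c1`: 310 nM
Compound 3 `Cc1ccc(-c2cc(Br)ccc2OCc2ccc(F)cc2F)n1-c1cc(N)cc(C(=O)O)c1`: 50 nM

In an in vivo ADME assay on the whole organism for pharmacokinetics, with Rattus norvegicus as the target, at a dose of 3 mg/kg by the oral route (on this read-out higher numbers stand for higher exposure at the dose given and lower numbers for lower exposure), compound 3 gives the lowest of the three numbers, and both gaps lie beyond the scatter: compound 1 sits higher at 230 nM, and compound 2 higher still at 310 nM. Compound 4 `CC(=O)Nc1cc(C(=O)O)cc(-n2c(C)ccc2-c2cc(Br)ccc2OCc2ccc(F)cc2F)c1` differs from compound 3 by acetyl in place of hydrogen on a nitrogen on an aromatic ring. Going by the values given here, no measured pair shows this change, so its direction is open. The two higher compounds lack the amino group, which leaves room for an upward step. The step from compound 3 to compound 4 is expected to be a 2.0-fold higher number from compound 3 to compound 4 (0.30 log units; within the scatter), a modest rise that may not exceed the scatter. Compound 4 is estimated at 100 nM, with a range from 30 nM to 350 nM.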

Compound 4, maximal plasma concentration: 1410 nM
Estimate against measurement, compound 4: 14-fold (1.15 log units) below; measured number above the stated range.
By their numbers in this assay, from the lowest: compound 3; then compounds 1 and 2 (each within the scatter of the next); then compound 4.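

In this assay, acetyl in place of hydrogen on this nitrogen gives a 28-fold higher number from compound 3 to compound 4 (1.45 log units; beyond the scatter), a large step. Going by these compounds alone, the earlier compounds differ from one another in several places, so only this pair shows that oral exposure responds strongly to this single change on the nitrogen. The data offer no measurement that explains the rise. The compounds shown leave open whether the gain is specific to acetyl or would also come with a propanoyl or methanesulfonyl group on the same nitrogen.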